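Adding a 3-Iodophenyl Group to a Weaker Adenosine Ligand

The source may report more compounds than this note shows. Statements on the series, on what has been measured and on what is new or still open speak of the compounds shown alone.

Compound 1 `CNc1nc(Cl)nc2c1ncn2[C@@H]1O[C@H](C(=O)NC2CC2)[C@@H](O)[C@H]1O` and compound 3 `O=C(NC1CC1)[C@H]1O[C@@H](n2cnc3c(NCc4cccc(I)c4)nc(Cl)nc32)[C@H](O)[C@@H]1O` differ in one place: 3-iodophenyl in place of hydrogen on a saturated chain carbon bound to a nitrogen on an aromatic ring. In an assay on CHO cells for displacement of a labelled ligand from adenosine receptor A3 (Homo sapiens) (a higher number here means a weaker inhibitor, a lower number a stronger inhibitor), compound 1 gives 2.82 nM and compound 3 gives 2.95 nM, so this change made a 1.0-fold higher number from compound 1 to compound 3 (0.02 log units; within the scatter). Compound 2 `CNc1nc(Cl)nc2c1ncn2[C@@H]1O[C@H](C(=O)N2CCC(Cc3ccccc3)CC2)[C@@H](O)[C@H]1O` differs from compound 1 in more than one place; the difference between the two cores is not broken down here. In this assay compound 2 gives 3470 nM, the highest of the three numbers and beyond the scatter from both others. Compound 4 `O=C([C@H]1O[C@@H](n2cnc3c(NCc4cccc(I)c4)nc(Cl)nc32)[C@H](O)[C@@H]1O)N1CCC(Cc2ccccc2)CC1` is not yet measured. It differs from compound 2 in the same way that compound 3 differs from compound 1: 3-iodophenyl in place of hydrogen on a saturated chain carbon bound to a nitrogen on an aromatic ring. Because this same change at the same place gave a 1.0-fold higher number from compound 1 to compound 3 (0.02 log units; within the scatter), the step now expected is a 1.4-fold lower number from compound 2 to compound 4 (0.14 log units; within the scatter), resting on that single earlier pair and allowing for some uncertainty about whether the change behaves alike on the weaker core. Compound 4 is therefore estimated at 2500 nM in this assay, with a range from 600 nM to 8000 nM.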

Compound 4, inhibition constant: 871 nM
Compound 4: the middle estimate sits 2.9-fold (0.46 log units) above what was measured, and the stated range covers the measured number.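

On the core of compound 2, the 3-iodophenyl change brought a real gain in this assay, with a 4.0-fold lower number from compound 2 to compound 4 (0.60 log units; beyond the scatter), whereas on the core of compound 1 it brought no change beyond the scatter. Going by these compounds alone, the same change therefore did not carry over at the same size from one core to the other: the same change on two cores in this assay, a 1.0-fold higher number (0.02 log units; within the scatter) from compound 1 to compound 3 and a 4.0-fold lower number (0.60 log units; beyond the scatter) from compound 2 to compound 4, 4.2-fold (0.62 log units) apart, beyond the scatter of two such steps With only two pairs, this shows that the core can alter the size of the step, but not why it does so or what the step would be on a third core.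

The compounds shown leave open whether the iodine itself matters to either step, since a plain phenyl or a 3-bromophenyl in the same place would separate the iodine from the ring that carries it. They also leave open how the change would behave on cores with other amides, such as an ethyl amide or a plain piperidine amide.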